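A few compounds are considered here, and "the series" means these few. Any claim that something is new, unique, unknown or untested is made for them only; others in the source may bear on it.

The shared core of compound 1 `O=C(Nc1ccnnc1)c1cc(N2C[C@H]3COC[C@H]3C2)ccc1OCc1ccccc1` carries an amide and a benzyloxy group, and the property followed here is an ADME assay on microsomes from liver (Homo sapiens) for metabolic stability; a lower number here means slower removal, a higher number faster removal of the compound. In this assay, for the measured compounds named here, compound 1 gives 4.3 mL.min-1.g-1, the higher of the two numbers measured so far. Compound 2 `O=C(Nc1ccnnc1)c1cc(N2CCNCC2)ccc1OCc1ccccc1` differs from compound 1 in one place; in this assay compound 2 gives 0.4 mL.min-1.g-1, and the step of an 11-fold lower number from compound 1 to compound 2 (1.03 log units; beyond the scatter) shows that a swap at this position can move the number a long way. Compound 3 `N#CC1CCN(c2ccc(OCc3ccccc3)c(C(=O)Nc3ccnnc3)c2)CC1` is the compound now in question, and it differs from compound 1 as follows: a group of 8 heavy atoms (6 carbon, 2 nitrogen; one six-membered non-aromatic ring with 1 hetero atom) in place of a group of 8 heavy atoms (6 carbon, 1 nitrogen, 1 oxygen; 2 five-membered non-aromatic rings with 1 hetero atom each), on an aromatic carbon. Going by the values given here, the only measured step that touches this position is the one from compound 1 to compound 2, which was large, but the group that entered there is a different one, so it serves only as a loose guide. A decrease is expected, though a smaller one than that step, and the change expected is a 1.7-fold lower number from compound 1 to compound 3 (0.24 log units; within the scatter). Compound 3 is therefore estimated at 2.5 mL.min-1.g-1, within a range from 1 mL.min-1.g-1 to 6 mL.min-1.g-1.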

Compound 3, intrinsic clearance in microsomes: 5.5 mL.min-1.g-1
The estimate for compound 3 lay 2.2-fold (0.34 log units) below the measured number; the measured number falls inside the stated range.
By their numbers in this assay, from the lowest: compound 2; then compounds 1 and 3 (each within the scatter of the next).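

Putting 4-cyanopiperidin-1-yl in place of the group with two five-membered rings gives a 1.3-fold higher number from compound 1 to compound 3 (0.11 log units; within the scatter) in this assay, so in this measurement these two quite different groups cannot be told apart at this position, para to the benzyloxy group. For the compounds shown here, the direct swap of piperazin-1-yl for 4-cyanopiperidin-1-yl gives a 14-fold higher number from compound 2 to compound 3 (1.14 log units; beyond the scatter) and, for the first time, sets piperazin-1-yl against a single-ring group of the same six-membered size, showing that among the three groups seen here only piperazin-1-yl stands apart, with the lowest number. Nothing available explains why this group differs from the other two.

From the compounds shown here alone, it remains open whether the low number depends on the second ring nitrogen of piperazin-1-yl and its hydrogen, a question that a 4-methylpiperazin-1-yl group or a morpholin-4-yl group at the same place would address. Going by these compounds, it is equally open whether the nitrile plays any part in the number for 4-cyanopiperidin-1-yl, which a plain piperidin-1-yl group would help to settle.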